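This account rests on a few compounds, and the source may have more. Where it says the series, first, only, none or still open, it means among the compounds named here.

Measured so far in a functional assay on U-251 cells (Homo sapiens) for inhibition, read by sulforhodamine B assay, with a stated time of 48 h, tested at 10 uM; a higher number here means more inhibition at the concentration tested (going by the name of the read-out), a lower number less inhibition:
compound 1 `COc1ccc(-c2cn3ccnc3c(-c3ccc4ncn(C5CCCCC5)c4c3)n2)cc1`: 80.9%
compound 2 `c1cn2cc(-c3ccsc3)nc(-c3ccc4ncn(C5CCCCC5)c4c3)c2n1`: 6.09%
compound 3 `CCc1ccc(-c2cn3ccnc3c(-c3ccc4ncn(Cc5ccccc5)c4c3)n2)cc1`: 46.1%

Compound 3 stands second highest of the three numbers; compound 1 lies above it and compound 2 lies well below it, both gaps beyond the scatter. Among the measured compounds shown here, compound 3 and compound 1 differ in two places, so no single step connects them; their two values simply show compound 1 higher. For the measured compounds named here, the only single step measured, a number 74.8 percentage points lower from compound 1 to compound 2 (beyond the scatter), exchanged the group at the same position that changes here, and it was large.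

Compound 4 `c1ccc(Cn2cnc3ccc(-c4nc(-c5cccc6ccccc56)cn5ccnc45)cc32)cc1` is not yet measured. Its difference from compound 3: naphthalen-1-yl in place of 4-ethylphenyl on an aromatic carbon. Going by the values given here, no measured step exchanges one carbon-only aromatic group for another at this position; the recorded step replaced 4-methoxyphenyl with thiophen-3-yl and cannot be carried over directly. The direction is therefore open: a step of modest size in this assay in either direction, or none beyond the scatter, is plausible, with the downside weighted somewhat because a number 74.8 percentage points lower from compound 1 to compound 2 (beyond the scatter) showed how much can be lost when this group is changed.

Compound 4 is expected near 38%, within 10% to 70%. This estimate corresponds to an expected step of a number 8.1 percentage points lower from compound 3 to compound 4 (within the scatter).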

Compound 4, a percentage reported as inhibition, at one concentration (the size of the read-out at that concentration, not a potency): 5.53%
Compound 4: middle estimate off by 32.5 percentage points, on the high side, and the stated range ends above it.
By their numbers in this assay, from the lowest: compounds 4 and 2 (each within the scatter of the next); then compound 3; then compound 1.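

In this assay, a number 40.6 percentage points lower from compound 3 to compound 4 (beyond the scatter), so a large loss at this position is not confined to the exchange of 4-methoxyphenyl for thiophen-3-yl, where a number 74.8 percentage points lower from compound 1 to compound 2 (beyond the scatter). The new step is an exchange of one carbon-only aromatic group for another, with no hydrogen-bond donors or acceptors on either side, and the entering naphthalen-1-yl has more heavy atoms than the leaving 4-ethylphenyl, so neither a ring with a heteroatom nor a smaller group is needed for the loss. Among the compounds shown here, the drop also appears with the group on the other side of the core that compound 3 and compound 4 share, which differs from the one in compound 1 and compound 2, but no measurement at hand explains why the number falls in either pair.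

From the compounds shown here alone, whether a single phenyl ring carrying an amine or a carboxylic acid in place of the ethyl group would hold the inhibition of compound 3 remains open, as does the outcome for naphthalen-2-yl. The separate contributions of the 4-methoxyphenyl and 4-ethylphenyl groups also stay unresolved, since compound 1 and compound 3 differ in two places.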